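The source may hold more compounds than are shown below. What is called first, only, known or untested is meant among the compounds shown, and "the series" means these compounds.

Measured compounds:
- Compound 1, `Cc1c(-c2ccccc2)sc(N)c1C(=O)c1ccc(Cl)cc1`: 1%
- Compound 2, `CC(C)(C)Cc1c(-c2ccncc2)sc(N)c1C(=O)c1ccc(Cl)cc1`: 6%

Of the compounds shown here, two sharing one core have been tested in an assay on CHO cells for displacement of a labelled ligand from adenosine receptor A3 (Homo sapiens), read by scintillation counting, tested at 10 uM; on this read-out lower numbers stand for less inhibition and higher numbers for more inhibition at the one concentration tested (going by the name of the read-out). Compound 1 gives 1%, and compound 2 gives 6%. These two numbers lie within the usual scatter of each other, so on this evidence the inhibition in this assay is level between compound 1 and compound 2; both numbers are low on this read-out.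

Compound 3, `CC(C)(C)Cc1c(-c2ccccc2)sc(N)c1C(=O)c1ccc(Cl)cc1`, has not yet been measured in this assay. It differs from compound 2 in one place: phenyl in place of pyridin-4-yl on an aromatic carbon. Compound 3 thus carries the neopentyl group of compound 2 together with the phenyl ring of compound 1.

Among the compounds with values here, with no measured step to guide the expectation, and with both known values sitting close to the floor of the read-out, the step expected from compound 2 to compound 3 in this assay is small, a number 3 percentage points lower from compound 2 to compound 3 (within the scatter), and not beyond the scatter in either direction. The value estimated for compound 3 in this assay is 3%, with a likely range from 0% to 15%.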

Compound 3, a percentage reported as inhibition, at one concentration (the size of the read-out at that concentration, not a potency): 1%
Compound 3: the middle estimate sits 2 percentage points above what was measured; the range from low to high includes it.
By their numbers in this assay, from the lowest: compounds 1, 3 and 2 (each within the scatter of the next).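

Exchanging pyridin-4-yl for phenyl on the aromatic carbon next to the ring sulfur gives a number 5 percentage points lower from compound 2 to compound 3 (within the scatter) in this assay, so in this pair the ring nitrogen of pyridin-4-yl makes no difference that this read-out can separate from scatter. Placing tert-butyl in place of hydrogen on the saturated chain carbon gives no change at the digits printed from compound 1 to compound 3 (within the scatter) in this assay, which adds a second single-place comparison and shows that this change, too, gives no readable difference while the numbers stay low. No separate measurement bears on why these compounds read as they do.

With all three compounds low on this read-out, these pairs cannot tell whether either change would matter on a compound that shows clear inhibition. On these data alone, it also remains open whether an amine or a carboxylic acid in place of phenyl on this carbon, or a longer chain in place of neopentyl, would lift the inhibition clear of the scatter.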